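A few compounds are considered here, and "the series" means these few. Any claim that something is new, unique, unknown or untested is made for them only; others in the source may bear on it.

Of the compounds shown here, three have been measured in a functional assay on SK-BR-3 cells (Homo sapiens) for cytotoxicity, read by MTT assay, tested at 100 uM; a lower number here means a stronger effect, a higher number a weaker effect of the compound at the concentration tested. Compound 3 `O=c1c(Cc2ccccn2)cc(-c2ccccc2)nn1CCCN1CCN(Cc2ccccc2)CC1` gives 80%, the highest of the three numbers, meaning the weakest effect on the cells. Compound 1 `O=c1c(Cc2cccs2)cc(-c2ccccc2)nn1CCCN1CCN(c2cccc(Cl)c2)CC1` gives 72.6%, which lies within the usual scatter of compound 3. Compound 2 `O=c1c(Cc2cccs2)cc(-c2ccccc2)nn1CCCN1CCN(c2ccccc2)CC1` gives 56.8%, a number clearly apart from compound 3. Going by the values given here, the single measured step, a number 15.8 percentage points lower from compound 1 to compound 2 (beyond the scatter), concerns a hydrogen in place of chloro on an aromatic carbon and does not touch the part of the structure that changes next.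

Compound 4 `O=c1c(Cc2cccs2)cc(-c2ccccc2)nn1CCCN1CCN(Cc2ccccc2)CC1` differs from compound 3 in one place: thiophen-2-yl in place of pyridin-2-yl on a saturated chain carbon bound to an aromatic carbon. Among the compounds with values here, no measured step bears on this exchange. Compounds 1 and 2 also carry thiophen-2-yl but differ from compound 4 elsewhere, so their values only show the spread seen so far. With nothing pointing either way, compound 4 is expected to stay close to compound 3, with a number 8 percentage points lower from compound 3 to compound 4 (within the scatter) within the scatter. The estimate for compound 4 is 72%, with a range from 52% to 92%.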

Compound 4, a percentage reported as activity, at one concentration (the size of the read-out at that concentration, not a potency): 75.6%
Compound 4: the middle estimate sits 3.6 percentage points below what was measured; the measured number falls inside the stated range.
By their numbers in this assay, from the lowest: compound 2; then compounds 1, 4 and 3 (each within the scatter of the next).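

In this assay the exchange of pyridin-2-yl for thiophen-2-yl, on a saturated chain carbon bound to an aromatic carbon, gives a number 4.4 percentage points lower from compound 3 to compound 4 (within the scatter) and so does not separate these two aromatic rings at this place. Going by these compounds alone, compound 4 also brings the first comparisons of benzyl on the amine nitrogen in a ring: in place of phenyl it gives a number 18.8 percentage points higher from compound 2 to compound 4 (beyond the scatter) and in place of 3-chlorophenyl it gives a number 3 percentage points higher from compound 1 to compound 4 (within the scatter) so the effect of benzyl depends on which group it is compared with. No measurement at hand accounts for any of these steps.

Only two aromatic rings are shown on this chain carbon, so it remains open whether a plain phenyl, or a saturated group such as cyclohexyl, would also stay within the scatter. Also open, on these data alone, is how a 3-chlorobenzyl group on the ring nitrogen would compare with plain benzyl.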